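The source may report more compounds than this note shows. Statements on the series, on what has been measured and on what is new or still open speak of the compounds shown alone.

Of the compounds shown here, three sharing one core have been measured in a functional assay on PC-3 cells (Homo sapiens) for cytotoxicity, read by MTT assay, with a stated time of 72 h; on this read-out higher numbers stand for weaker inhibition of growth and lower numbers for stronger inhibition of growth: compound 1 `CCCCOC(=O)Nc1ccc([Se]C#N)cc1` gives 12400 nM, compound 2 `CC(C)COC(=O)Nc1ccc([Se]C#N)cc1` gives 21600 nM, and compound 3 `CCOC(=O)Nc1ccc([Se]C#N)cc1` gives 9900 nM. Compound 3 thus holds the lowest of the three numbers, though its gap to compound 1 lies within the scatter. Compound 4 `N#C[Se]c1ccc(NC(=O)Oc2ccccc2)cc1` differs from compound 3 by phenyl in place of ethyl on an oxygen next to a carbonyl group. The measured steps all vary the group on that same oxygen: a 1.7-fold higher number from compound 1 to compound 2 (0.24 log units; within the scatter), a 1.3-fold lower number from compound 1 to compound 3 (0.10 log units; within the scatter) and a 2.2-fold lower number from compound 2 to compound 3 (0.34 log units; beyond the scatter). Those changes moved the numbers little, but none placed an aromatic ring there, so their bearing on compound 4 is loose. The expected step is a 1.0-fold higher number from compound 3 to compound 4 (0.00 log units; within the scatter). Compound 4 is therefore estimated at 10000 nM, within a range from 3000 nM to 35000 nM.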

Compound 4, concentration for 50% growth inhibition: 9100 nM
Estimate against measurement, compound 4: 1.1-fold (0.04 log units) above, within the range that was stated.
By their numbers in this assay, from the lowest: compounds 4, 3, 1 and 2 (each within the scatter of the next, the first and the last beyond it).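

In this assay, an aromatic ring on the oxygen next to a carbonyl group does about as well as a straight saturated chain: phenyl in place of ethyl gives a 1.1-fold lower number from compound 3 to compound 4 (0.04 log units; within the scatter), and phenyl in place of butyl gives a 1.4-fold lower number from compound 1 to compound 4 (0.13 log units; within the scatter). Only the change from isobutyl, with a 2.4-fold lower number from compound 2 to compound 4 (0.38 log units; beyond the scatter), goes beyond the scatter, and that step is modest. No measurement shown here explains these numbers.

Still open, on these data alone, is how benzyl, pyridyl or a longer chain such as octyl would read at this oxygen. Also open, as far as these compounds go, is whether a phenyl ring carrying a methoxy group or an amine would keep these numbers.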